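This account rests on a few compounds, and the source may have more. Where it says the series, first, only, none or still open, it means among the compounds named here.

In a functional assay on CHO cells for antagonist activity at transient receptor potential cation channel subfamily V member 1 (Rattus norvegicus) (a higher number here means a weaker inhibitor, a lower number a stronger inhibitor), compound 1 `CC(C(=O)NCc1ccc(Br)cc1)c1ccc(NS(C)(=O)=O)c(F)c1` gives 250 nM.
In this assay compound 2 `CC(C(=O)NCc1ccc(C(F)(F)F)cc1)c1ccc(NS(C)(=O)=O)c(F)c1` gives 274 nM.
In this assay compound 3 `Cc1ccc(CNC(=O)C(C)c2ccc(NS(C)(=O)=O)c(F)c2)cc1` gives 930 nM.

Compound 3 stands highest of these three numbers: a 3.7-fold higher number from compound 1 to compound 3 (0.57 log units; beyond the scatter), and a 3.4-fold higher number from compound 2 to compound 3 (0.53 log units; beyond the scatter), while a 1.1-fold higher number from compound 1 to compound 2 (0.04 log units; within the scatter). Compound 4 `CC(C)c1ccc(CNC(=O)C(C)c2ccc(NS(C)(=O)=O)c(F)c2)cc1` differs from compound 3 by isopropyl in place of methyl on an aromatic carbon. Among the compounds with values here, no measured step pairs methyl against isopropyl at this position; the steps that bear on it are those from compound 1 and compound 2 to compound 3, where methyl gave the highest number. A lower number is therefore expected for compound 4, by a modest amount, a 2.1-fold lower number from compound 3 to compound 4 (0.32 log units; beyond the scatter). Compound 4 is estimated at 450 nM, with a range from 180 nM to 1300 nM.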

Compound 4, inhibition constant: 144 nM
Compound 4: the middle estimate sits 3.1-fold (0.49 log units) above what was measured, and the stated range ends above it.
By their numbers in this assay, from the lowest: compounds 4, 1 and 2 (each within the scatter of the next); then compound 3.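

In this assay, within the data shown here, isopropyl in place of methyl gives a 6.5-fold lower number from compound 3 to compound 4 (0.81 log units; beyond the scatter) and this is a larger step than any among the earlier compounds. Set against trifluoromethyl and bromo, isopropyl gives a 1.9-fold lower number from compound 2 to compound 4 (0.28 log units; within the scatter) and a 1.7-fold lower number from compound 1 to compound 4 (0.24 log units; within the scatter) and both steps lie within the scatter, so methyl alone of these four groups stands apart at this position. Nothing available here explains this result. The compounds shown leave open how a tert-butyl group, a longer chain such as n-butyl, or a methoxy group would read at this position in this assay.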